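Ester prodrugs of a flavonol core: half-life notes

A few compounds are considered here, and "the series" means these few. Any claim that something is new, unique, unknown or untested is made for them only; others in the source may bear on it.

Measured so far:
compound 1 `CC(C)(C)OC(=O)NCCCC(=O)Oc1cc(-c2oc3cc(O)cc(O)c3c(=O)c2O)ccc1O` — 0.000208 h
compound 2 `CC(C)(C)OC(=O)N[C@H]1CC[C@@H](C(=O)Oc2cc(-c3oc4cc(O)cc(O)c4c(=O)c3O)ccc2O)CC1` — 0.000331 h

In a physicochemical assay for pharmacokinetics (on this read-out higher numbers stand for a longer-lived compound and lower numbers for a shorter-lived compound), compound 1 gives the lower of the two numbers, and compound 2 stands within the scatter of it, so no order between them is claimed. Compound 3 `NCCCC(=O)Oc1cc(-c2oc3cc(O)cc(O)c3c(=O)c2O)ccc1O` differs from compound 1 by hydrogen in place of tert-butoxycarbonyl on an amine nitrogen. Among the compounds with values here, no comparable step is available among the measured pair, so the effect of this change is open; on the numbers at hand no step beyond the scatter is expected in this assay, in either direction. Compound 3 is therefore estimated at 0.00021 h (range 0.00007 h to 0.0007 h), a step of a 1.0-fold higher number from compound 1 to compound 3 (0.00 log units; within the scatter) expected.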

Compound 3, half-life: 0.000000194 h
The estimate for compound 3 lay 1100-fold (3.03 log units) above the measured number, and the stated range ends above it.
By their numbers in this assay, from the lowest: compound 3; then compounds 1 and 2 (each within the scatter of the next).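

On the amine nitrogen, exchanging tert-butoxycarbonyl for hydrogen has a large effect in this assay, giving a 1100-fold lower number from compound 1 to compound 3 (3.03 log units; beyond the scatter). This is the first step in the series shown to lie beyond the scatter, and it makes the group on this nitrogen a sensitive point, at least on this chain. Nothing available bears on the reason for this drop.

On these data alone, whether an acetyl amide or a methyl carbamate on this nitrogen would keep the number near that of compound 1 remains open. Also open, as far as these compounds go, is whether a longer chain would alter the size of the step.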